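Sulfo in Place of Methyl: an Untested Step

This account rests on a few compounds, and the source may have more. Where it says the series, first, only, none or still open, it means among the compounds named here.

Compound 1, `Nc1nc2ccc(C(=O)C(F)(F)F)cc2s1`: > 10 mg/kg
Compound 2, `CCCn1c(=N)sc2cc(OC(F)(F)F)ccc21`: 4.5 mg/kg

Of the compounds shown here, two have been measured in a functional assay on the whole organism with Rattus norvegicus as the target; on this read-out higher numbers stand for an effect only at larger amounts of compound and lower numbers for an effect already at smaller amounts. Among the measured compounds shown here, compound 2 gives 4.5 mg/kg, the only numerical value so far; it stands alone, with nothing to be ordered against. For compound 1 the read-out is a limit, > 10 mg/kg, and not a number; one of the two values sits at this limit, (the limit of > 10 mg/kg in this assay, at which 1 of the 2 values shown sits). For the measured compounds named here, no pair of measured compounds differs in a single place, so no measured step exists.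

Compound 3, `N=c1sc2cc(OC(F)(F)F)ccc2n1CCS(=O)(=O)O`, has not been measured. It differs from compound 2 by sulfo in place of methyl on a saturated chain carbon, two bonds along the chain from an aromatic nitrogen. Going by the values given here, with no measured step to rest on, the expectation for this change is a move toward larger doses in this assay, beyond the usual scatter, with a real chance that only a limit is recorded. The step from compound 2 to compound 3 is expected to be a 3.3-fold higher number from compound 2 to compound 3 (0.52 log units; beyond the scatter). Compound 3 is accordingly estimated at 15 mg/kg, within a range from 5 mg/kg to 45 mg/kg.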

Compound 3, dose for half-maximal effect: > 10 mg/kg
Compound 3 ended at the assay's limit; the forecaster's own chance of this, stated with the estimate: 55%; the middle value lies beyond the limit too.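

In this assay, among the compounds shown here, sulfo in place of methyl on a saturated chain carbon, two bonds along the chain from an aromatic nitrogen, gives an at least 2.2-fold higher number from compound 2 to compound 3 (0.34 log units; beyond the scatter), the first measured step here, and it shows that this end of the chain is not indifferent to what stands on it. Compound 3 gives > 10 mg/kg, which is a limit of the assay and not a number, so the step fixes only the smallest size the change can have. The full size of the change therefore stays out of reach, and the assay's ceiling now holds most of the set: the limit of > 10 mg/kg in this assay, at which 2 of the 3 values shown sit.

On these data alone, how far compound 3 lies past that limit remains open. So does whether a carboxylic acid, an amine or a hydroxyl on the same chain carbon would move the dose as far as sulfo does.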